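Extending the ester chain on compound 2

The source may hold more compounds than are shown below. What is called first, only, known or untested is meant among the compounds shown, and "the series" means these compounds.

Measured so far in a functional assay on the whole organism with Scenedesmus acutus as the target, with a stated time of 20 h; a lower number here means a stronger inhibitor, a higher number a weaker inhibitor (half-maximal inhibitory concentration):
- compound 1 `CCOC(=O)c1cc(N2C(=O)C3=C(CCCC3)C2=O)c(F)cc1Cl` gives 87.1 nM
- compound 2 `CCOC(=O)c1cc(N2C(=O)C3=C(CCCC3)C2=O)ccc1Cl` gives 2140 nM
- compound 3 `CCCOC(=O)c1cc(N2C(=O)C3=C(CCCC3)C2=O)c(F)cc1Cl` gives 66.1 nM

Compound 2 has the highest number of the three, and the gap to compound 3 is wider than the gap to compound 1. Its large distance from compound 1 is shown by the step of a 25-fold higher number from compound 1 to compound 2 (1.39 log units; beyond the scatter) (hydrogen in place of fluoro on an aromatic carbon). That step sets the level of compound 2 but says nothing about the ester chain.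

The next entry is compound 4 `CC(C)COC(=O)c1cc(N2C(=O)C3=C(CCCC3)C2=O)ccc1Cl`, still unmeasured. The change is isopropyl in place of methyl on a saturated chain carbon bound to an oxygen next to a carbonyl group (isopropyl in place of methyl on a saturated chain carbon bound to an oxygen next to a carbonyl group, or ethoxycarbonyl to isobutoxycarbonyl).

Among the compounds with values here, only one measured step touches this chain, namely a 1.3-fold lower number from compound 1 to compound 3 (0.12 log units; within the scatter) (a small lengthening). It was seen with fluoro present, and no branched chain and no chain change without fluoro has been measured. A small shift is therefore expected in this assay, probably none beyond the scatter, and if anything towards a lower number.

The expected outcome is a 1.3-fold lower number from compound 2 to compound 4 (0.10 log units; within the scatter) (an estimate with wide margins). Compound 4 is estimated at 1700 nM (expected range 650 nM to 4500 nM).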

Compound 4, half-maximal inhibitory concentration: 15500 nM
For compound 4 the middle estimate is 9.1-fold (0.96 log units) below the measured one; the measured number lies above the stated range.
By their numbers in this assay, from the lowest: compounds 3 and 1 (each within the scatter of the next); then compound 2; then compound 4.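

In this assay the ester chain is not a silent position, since going from ethoxycarbonyl to isobutoxycarbonyl gives a 7.2-fold higher number from compound 2 to compound 4 (0.86 log units; beyond the scatter) and makes compound 4 the highest number in the series. Within the data shown here, the only earlier step on this chain, a 1.3-fold lower number from compound 1 to compound 3 (0.12 log units; within the scatter), stayed within the scatter, so the small effect of that straight lengthening in the fluoro compounds does not carry over to this isobutyl change in the compounds without fluoro. Nothing available here bears on why the number rises with this change.

Going by these compounds, the two chain steps differ both in the chain that enters and in the presence of fluoro on the aromatic carbon, so it remains open whether the rise belongs to the branch, to the added length, or to the absence of fluoro. A straight butoxycarbonyl chain on the core of compound 2 would separate branch from length, and an isobutoxycarbonyl chain on the core of compound 1 would show whether fluoro changes the size of the step.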